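Chloro to bromo on the anilino ring of compound 1

This account rests on a few compounds, and the source may have more. Where it says the series, first, only, none or still open, it means among the compounds named here.

Measured compounds:
- compound 1, `Clc1cccc(Nc2ncnc3ccc(NCc4ccc5c(c4)OCCCCO5)cc23)c1`: 21.3 ug/mL
- compound 2, `Clc1cccc(Nc2ncnc3ccc(NCc4ccc5c(c4)OCCCO5)cc23)c1`: 4.28 ug/mL
- compound 3, `O=C(Nc1ccc2ncnc(Nc3cccc(Cl)c3)c2c1)C1COc2ccccc2O1`: 52.2 ug/mL

In a functional assay on MCF7 cells (Homo sapiens) for antiproliferative activity, read by WST assay, with a stated time of 48 h (a higher number here means a weaker inhibitor, a lower number a stronger inhibitor), compound 1 gives 21.3 ug/mL, the second highest of the three numbers. Its nearest neighbour is compound 3, which in this assay gives 52.2 ug/mL, a higher number that lies beyond the scatter. The furthest is compound 2, which in this assay gives 4.28 ug/mL, a lower number, also beyond the scatter. Among the compounds with values here, compound 2 and compound 3 each differ from compound 1 in more than one place, so no single step among the measured compounds can be isolated.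

Compound 4, `Brc1cccc(Nc2ncnc3ccc(NCc4ccc5c(c4)OCCCCO5)cc23)c1`, has not yet been measured. It differs from compound 1 by a single change: bromo in place of chloro on an aromatic carbon. Within the data shown here, no measured pair shows this exchange, so the size of the step rests on the change alone. A halogen swap of this kind at the same position is usually a small move, and the expected step of a 1.3-fold lower number from compound 1 to compound 4 (0.12 log units; within the scatter) is none beyond the scatter, with a slight lean toward a lower number.

Compound 4 is therefore expected to give about 16 ug/mL in this assay, within a range from 6 ug/mL to 45 ug/mL.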

Compound 4, half-maximal inhibitory concentration: 32.1 ug/mL
Estimate against measurement, compound 4: 2.0-fold (0.30 log units) below; the measured number falls inside the stated range.
By their numbers in this assay, from the lowest: compound 2; then compounds 1, 4 and 3 (each within the scatter of the next, the first and the last beyond it).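

In this assay, within the data shown here, the exchange on the anilino ring reads as a 1.5-fold higher number from compound 1 to compound 4 (0.18 log units; within the scatter) and is the first step that isolates a single change. Among these compounds, with the rest of compound 1 held fixed, 3-chlorophenyl and 3-bromophenyl therefore cannot be told apart at this place on the ring, which the earlier compounds could not show as each differs from compound 1 in more than one place. No measurement among the data shown accounts for this result.

The compounds shown leave open whether a group other than chloro or bromo at this place, such as fluoro, iodo, methyl, methoxy, trifluoromethyl or nitrile, or simply hydrogen, would shift the number beyond the scatter. Among the compounds shown here, also open is whether bromo in place of chloro would read the same with the different side chains of compound 2 and compound 3, since the single step seen here was taken only on compound 1.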